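This account rests on a few compounds, and the source may have more. Where it says the series, first, only, none or still open, it means among the compounds named here.

Compound 1 `O=c1cc(Cn2cc(CCCO)nn2)c2ccc(O)cc2o1` gives > 100000 nM in a functional assay on CFPAC-1 cells (Homo sapiens) for inhibition, read by MTT assay, with a stated time of 72 h; a higher number here means a weaker inhibitor, a lower number a stronger inhibitor.
Compound 2 `O=c1cc(Cn2cc(CCCCO)nn2)c2ccc(O)cc2o1` gives > 100000 nM in this assay.
Compound 3 `O=c1cc(Cn2cc(CCc3ccccc3)nn2)c2ccc(O)cc2o1` gives > 100000 nM in this assay.

Each of these three values is a limit of this assay, not a number. Compound 2 therefore stands at that limit, and compound 1 and compound 3 stand there too, so that the limit of > 100000 nM in this assay, at which 3 of the 3 values shown sit, is the whole of the evidence on the shared core. The steps among them, a step that the two limits leave unreadable from compound 1 to compound 2, a step that the two limits leave unreadable from compound 1 to compound 3 and a step that the two limits leave unreadable from compound 2 to compound 3, cannot be read in size or direction; they show only that a 3-hydroxypropyl, a 4-hydroxybutyl and a 2-phenylethyl on the five-membered ring all leave the value at the limit.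

Compound 4 `O=c1cc(Cn2cc(-c3ccc(Br)cc3)nn2)c2ccc(O)cc2o1` has not yet been measured in this assay. It differs from compound 2 by 4-bromophenyl in place of 4-hydroxybutyl on an aromatic carbon. Among the compounds with values here, no measured step bears directly on this change, since the aromatic ring now sits on the ring carbon itself, where every measured compound carries a saturated chain. With three compounds at the limit, the expectation for compound 4 is that this assay again reports a limit, so the estimated step from compound 2 to compound 4 is a number no higher from compound 2 to compound 4 (the limit leaves the size open). Compound 4 is accordingly expected to give about 100000 nM, with a range from 10000 nM to 1000000 nM.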

Compound 4, half-maximal inhibitory concentration: 52900 nM
For compound 4 the middle estimate is 1.9-fold (0.28 log units) above the measured one; measured number inside the range.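

In this assay compound 4 gives 52900 nM, the first number rather than a limit on the shared core, and it carries 4-bromophenyl on the aromatic carbon of the five-membered ring, where compound 1, compound 2 and compound 3 carry saturated chains. The change reads as an at least 1.8-fold lower number from compound 2 to compound 4 (0.27 log units; that floor lies within the scatter), as an at least 1.8-fold lower number from compound 3 to compound 4 (0.27 log units; that floor lies within the scatter) and as an at least 1.8-fold lower number from compound 1 to compound 4 (0.27 log units; that floor lies within the scatter); each of these is only a floor that lies within the scatter, so the result places compound 4 off the limit without fixing the size of any step, and the steps among the three earlier compounds remain unreadable. Any reading of this change rests on one number set against limits: the limit of > 100000 nM in this assay, at which 3 of the 4 values shown sit.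

The compounds shown leave open whether the bromine or the aromatic ring itself goes with the move off the limit, which a plain phenyl, a 4-chlorophenyl or a 4-methoxyphenyl on the same carbon would separate. They also leave open what a benzyl, an amine or a carboxylic acid at this position would give, and whether the hydroxy group on the core matters at all.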